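The source may hold more compounds than are shown below. What is called first, only, known or untested is meant among the compounds shown, and "the series" means these compounds.

In a functional assay on MCF7 cells (Homo sapiens) for inhibition, read by XTT assay, with a stated time of 48 h (a higher number here means a weaker inhibitor, a lower number a stronger inhibitor), compound 1 `CCC(/C=C(\COC(C)=O)C(=O)c1ccc(OC)cc1)CC` gives 13700 nM. Going by the values given here, compound 2 `CCC(/C=C(\CCOC(C)=O)C(=O)c1ccc(OC)cc1)CC` returns only a limit of the assay, > 100000 nM, so where it stands is known just as a bound and not as a number; it is the single value sitting at the limit of > 100000 nM in this assay, at which 1 of the 2 values shown sits. Among the compounds with values here, the one measured step, an at least 7.2-fold higher number from compound 1 to compound 2 (0.86 log units; beyond the scatter), concerns the acetoxy-bearing chain and not the group on the double-bonded chain carbon, so it says nothing directly about the change to compound 3 `COc1ccc(C(=O)/C(=C/c2ccccc2Cl)CCOC(C)=O)cc1`, which is 2-chlorophenyl in place of pentan-3-yl on a double-bonded chain carbon bound to a double-bonded chain carbon. Within the data shown here, the data hold no step in which a pentan-3-yl is exchanged for an aryl group, and the starting point is itself a limit. The direction and size of an at least 2.5-fold lower number from compound 2 to compound 3 (0.39 log units; beyond the scatter) can therefore be expected only loosely. Compound 3 is estimated in this assay at 40000 nM, between 8000 nM and 200000 nM, with a real chance that another limit is all that is returned.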

Compound 3, half-maximal inhibitory concentration: > 100000 nM
Compound 3: no number, only a limit (the forecaster's own chance of this, stated with the estimate: 45%); middle value at least 2.5-fold (0.39 log units) from the limit.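

No new step can be read from compound 2 to compound 3, since each stands only as a limit: the limit of > 100000 nM in this assay, at which 2 of the 3 values shown sit. On these data alone, whether 2-chlorophenyl in place of pentan-3-yl changes inhibition at all stays open, as does how far either compound lies past that limit.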